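Nine-substituent change on the adenosine receptor series

The compounds below may be only part of what the source reports. "The series", "measured", "known", "first", "only" and "open" are said of these compounds alone.

Within the data shown here, compound 1 `CC(C)n1cnc2ncnc(N)c21` is the only member of the set with a numerical reading in an assay on CHO cells for displacement of a labelled ligand from adenosine receptor A1 (Homo sapiens); a higher number here means a weaker inhibitor, a lower number a stronger inhibitor; there compound 1 gives 20000 nM. Among the measured compounds shown here, the one other value shown is a limit. Compound 2 `CC(C)Cn1cnc2ncnc(N)c21` carries isobutyl in place of isopropyl on the aromatic nitrogen. In this assay compound 2 reaches only a limit of the assay, > 100000 nM. The measured step is an at least 5.0-fold higher number from compound 1 to compound 2 (0.69 log units; beyond the scatter), and its size rests on (the limit of > 100000 nM in this assay, at which 1 of the 2 values shown sits).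

Compound 3 `CC(O)Cn1cnc2ncnc(N)c21` is not yet measured. It differs from compound 1 by 2-hydroxypropyl in place of isopropyl on an aromatic nitrogen. For the measured compounds named here, the single measured step bears on it only loosely: lengthening the chain on the aromatic nitrogen cost potency, as an at least 5.0-fold higher number from compound 1 to compound 2 (0.69 log units; beyond the scatter) shows, and the 2-hydroxypropyl chain is likewise one heavy atom longer than isopropyl. A modest weakening is therefore expected, as the step of a 2.3-fold higher number from compound 1 to compound 3 (0.35 log units; beyond the scatter). Compound 3 is estimated at 45000 nM, with a range from 12000 nM to 200000 nM, and a fair chance of another limit.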

Compound 3, inhibition constant: > 100000 nM
Compound 3: a limit, no number; the forecaster's own chance of this, stated with the estimate: 40%; at least 2.2-fold (0.34 log units) between middle value and limit.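

In this assay, 2-hydroxypropyl in place of isopropyl on the aromatic nitrogen gives an at least 5.0-fold higher number from compound 1 to compound 3 (0.69 log units; beyond the scatter), so isobutyl is no longer the only replacement of isopropyl at this position that gives a weaker reading than compound 1. As far as these compounds go, compound 3 reaches a limit of the assay, > 100000 nM, so the true size of this loss remains unknown. The hydroxy in place of methyl, which separates compound 2 from compound 3, gives a step that cannot be read, and any effect of this change stays hidden at the limit: the limit of > 100000 nM in this assay, at which 2 of the 3 values shown sit.

From the compounds shown here alone, it remains open whether a shorter chain such as methyl or ethyl on the same nitrogen would give a stronger reading than compound 1. Going by these compounds, it also remains open whether an amine or a carboxylic acid on the chain would bring the reading back within the range of the assay.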